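The source may hold more compounds than are shown below. What is called first, only, known or untested is meant among the compounds shown, and "the series" means these compounds.

Values in a functional assay on the whole organism for inhibition, with Mus musculus as the target, with a stated time of 24 h, at a dose of 30 mg/kg by the oral route (a lower number here means less inhibition, a higher number more inhibition at the dose given (going by the name of the read-out)), for the measured compounds:
compound 1, `CN1CCN(CCCN(c2nc3cc(F)c(C(F)(F)F)cc3[nH]2)[C@@H]2CC[C@]3(c4ccc(C#N)cc4)C[C@H]23)CC1`: 94%
compound 2, `CN1CCN(CCCN(c2nc3cc(F)c(F)cc3[nH]2)[C@@H]2CC[C@]3(c4cccc(C#N)c4)C[C@@H]3C2)CC1`: 17%
compound 3, `CN1CCN(CCCN(c2nc3cc(Cl)c(Cl)cc3[nH]2)[C@@H]2CC[C@]3(c4cccc(C#N)c4)C[C@@H]3C2)CC1`: 97%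

Compound 3 sits at the top of these three numbers; compound 1 lies within the scatter of it and the two cannot be told apart, while compound 2 lies far below. Within the data shown here, the one step between measured compounds that differ in a single place is a number 80 percentage points higher from compound 2 to compound 3 (beyond the scatter), a large change that arises on the aromatic part of the core, not on the amine side chain.

Compound 4, `N#Cc1cccc([C@]23CC[C@@H](N(CN4CCCCC4)c4nc5cc(Cl)c(Cl)cc5[nH]4)C[C@H]2C3)c1`, awaits measurement. It differs from compound 3 by piperidin-1-yl in place of 2-(4-methylpiperazin-1-yl)ethyl on a saturated chain carbon bound to a nitrogen on an aromatic ring. Among the measured compounds shown here, no measured pair in this set alters that part of the molecule, so the step from compound 2 to compound 3 gives no direct guide, and the expectation rests only on compound 3 as the starting point. Compound 4 is therefore expected to give 70% in this assay, within a range from 30% to 97%. That expectation means a step of a number 27 percentage points lower from compound 3 to compound 4 (beyond the scatter), with wide uncertainty.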

Compound 4, a percentage reported as inhibition, in the whole organism at one dose (the size of the read-out at that dose, not a potency): 0%
Compound 4: the middle estimate sits 70 percentage points above what was measured, outside the stated range (below it).
By their numbers in this assay, from the lowest: compound 4; then compound 2; then compounds 1 and 3 (each within the scatter of the next).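

In this assay, the amine side chain proves decisive for this series, a point the earlier step on the aromatic part of the core could not show: with piperidin-1-yl in place of 2-(4-methylpiperazin-1-yl)ethyl on a saturated chain carbon bound to a nitrogen on an aromatic ring, the read-out shows a number 97 percentage points lower from compound 3 to compound 4 (beyond the scatter). The 5,6-dichloro-1H-benzimidazol-2-yl group is thus not sufficient on its own, as it is also carried by compound 4, which gives 0% in this assay. Nothing available explains this loss.

Read one bond further out, the change replaces 3-(4-methylpiperazin-1-yl)propyl with (piperidin-1-yl)methyl, so chain length and ring change together and their contributions cannot be separated. A 3-(piperidin-1-yl)propyl chain or a (4-methylpiperazin-1-yl)methyl group would be needed to pull the two apart.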